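This account rests on a few compounds, and the source may have more. Where it says the series, first, only, none or still open, it means among the compounds named here.

Measured in an ADME assay on HeLa cells (Homo sapiens) for cytotoxicity, read by resazurin assay, with a stated time of 65 h (a lower number here means that less compound is needed, a higher number that more compound is needed for the effect), so far:

- Compound 1 `CCc1cc(C(N)=O)c(NC(=O)c2n[nH]cc2[N+](=O)[O-])s1` gives > 20000 nM as a limit of the assay
- Compound 2 `O=C(Nc1cccc(C(F)(F)F)c1)c1ccc([N+](=O)[O-])o1` gives > 20000 nM as a limit of the assay

Neither compound has a number of its own. Both stand at the limit of > 20000 nM in this assay, at which 2 of the 2 values shown sit, and compound 2 is therefore known only by this limit.

Compound 3 `COc1cccc(NC(=O)c2ccc([N+](=O)[O-])o2)c1` keeps the shared core of compound 2 and changes one group. The difference is methoxy in place of trifluoromethyl on an aromatic carbon, which puts methoxy in place of trifluoromethyl on an aromatic carbon, meta to a large group. Among the measured compounds shown here, no measured pair here shows what a change of this kind does in this assay, and compound 2 offers only a limit as a starting point. No shift beyond the usual scatter is therefore expected, and a reading that again reaches the limit is the likeliest outcome. The estimated change is a step that the limit leaves unreadable from compound 2 to compound 3, a step expected to be no larger than the scatter. For compound 3 the expected value is 25000 nM, with an estimated range from 10000 nM to 50000 nM as its span.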

Compound 3, half-maximal effective concentration: > 20000 nM
Compound 3 ended at the assay's limit; the forecaster's own chance of this, stated with the estimate: 75%; the middle value does not contradict the limit.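

Compound 2 and compound 3 are both known only by a limit, so the exchange of trifluoromethyl for methoxy cannot be read as a step: the limit of > 20000 nM in this assay, at which 3 of the 3 values shown sit.

The compounds shown leave open what actual value any of them would have, and whether this exchange has any effect at all.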